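Swapping the side group on compound 3 for piperazine

The source may hold more compounds than are shown below. What is called first, only, known or untested is meant among the compounds shown, and "the series" means these compounds.

Measured in a functional assay on G-361 cells (Homo sapiens) for cytotoxicity, read by fluorescence, with a stated time of 72 h; a higher number here means a weaker inhibitor, a lower number a stronger inhibitor:
- Compound 1 `CSc1nc(NCc2ccc(-c3ccccn3)cc2)c2[nH]nc(C(C)C)c2n1`: 1400 nM
- Compound 2 `CC(C)c1n[nH]c2c(NCc3ccc(-c4ccccn4)cc3)nc(NCC(C)(C)O)nc12`: 48 nM
- Compound 3 `CC(C)c1n[nH]c2c(NCc3ccc(-c4ccccn4)cc3)nc(N3CCCCC3CCO)nc12`: 204 nM

Compound 3, at 204 nM, holds the middle of these three values. The gaps on either side are a 4.3-fold higher number from compound 2 to compound 3 (0.63 log units; beyond the scatter) and a 6.9-fold lower number from compound 1 to compound 3 (0.84 log units; beyond the scatter).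

Compound 4 `CC(C)c1n[nH]c2c(NCc3ccc(-c4ccccn4)cc3)nc(N3CCNCC3)nc12` carries piperazin-1-yl in place of 2-(2-hydroxyethyl)piperidin-1-yl, on the aromatic carbon between two ring nitrogen atoms: piperazin-1-yl in place of 2-(2-hydroxyethyl)piperidin-1-yl on an aromatic carbon.

For the measured compounds named here, no measured compound has this group. The closest guide is the swap of one nitrogen-linked group for another at this place, compound 2 against compound 3, which gave a 4.3-fold higher number from compound 2 to compound 3 (0.63 log units; beyond the scatter). The larger 29-fold lower number from compound 1 to compound 2 (1.46 log units; beyond the scatter) replaced methylsulfanyl, a different kind of change. A small shift toward a lower number in this assay, perhaps no more than the scatter, is therefore expected.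

The expected change is a 1.7-fold lower number from compound 3 to compound 4 (0.23 log units; within the scatter). For compound 4 the estimated value is 120 nM, with an expected range from 35 nM to 400 nM.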

Compound 4, half-maximal inhibitory concentration: 64 nM
For compound 4 the middle estimate is 1.9-fold (0.27 log units) above the measured one, and the stated range covers the measured number.
By their numbers in this assay, from the lowest: compounds 2 and 4 (each within the scatter of the next); then compound 3; then compound 1.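

In this assay, replacing 2-(2-hydroxyethyl)piperidin-1-yl with piperazin-1-yl on the aromatic carbon between two ring nitrogen atoms gives a 3.2-fold lower number from compound 3 to compound 4 (0.50 log units; beyond the scatter) and shows that a ring at this carbon needs no hydroxyl-bearing chain. Piperazin-1-yl and (2-hydroxy-2-methylpropyl)amino cannot be told apart, with a 1.3-fold higher number from compound 2 to compound 4 (0.12 log units; within the scatter), while replacing methylsulfanyl with piperazin-1-yl gives a 22-fold lower number from compound 1 to compound 4 (1.34 log units; beyond the scatter), so a second, quite different nitrogen-linked group also far outperforms methylsulfanyl. No measured evidence explains these differences.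

On these data alone, how a plain piperidin-1-yl ring, a morpholin-4-yl ring or a 4-methylpiperazin-1-yl group would compare at this carbon remains open.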